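The compounds below may be only part of what the source reports. "The series", "measured", "known", "first", "only" and "open" are said of these compounds alone.

Working notes on the series. Compound 1 `N#Cc1cccc(C#Cc2cccc(C(N)=O)c2)n1` reaches only the limit > 10000 nM in an assay on membranes from brain (strain Sprague-Dawley) for displacement of a labelled ligand from metabotropic glutamate receptor 5 (Rattus norvegicus), read by scintillation counting, with a stated time of 60 min; on this read-out higher numbers stand for weaker inhibition and lower numbers for stronger inhibition. Compound 3 `N#Cc1cccc(C#Cc2cccc(C#N)n2)c1` gives 8.2 nM in this assay, the higher of the two numbers shown, while compound 2 `COc1cc(C#N)cc(C#Cc2cccc(C)n2)c1` gives 1.29 nM. Among the measured compounds shown here, the one measured step, an at least 1200-fold lower number from compound 1 to compound 3 (3.08 log units; beyond the scatter), concerns the carbamoyl-to-cyano exchange on the other ring. That step is bounded by the limit of > 10000 nM in this assay, at which 1 of the 3 values shown sits. Compound 4 `N#Cc1cccc(C#Cc2cccc(F)n2)c1` differs from compound 3 by fluoro in place of cyano on an aromatic carbon. For the measured compounds named here, no measured step touches this group; compound 2, bearing methyl instead of cyano there, gives a lower number than compound 3. Exchanging cyano for fluoro is therefore expected to give no step beyond the scatter, a 1.5-fold higher number from compound 3 to compound 4 (0.17 log units; within the scatter). Compound 4 is estimated at 12 nM, between 3 nM and 50 nM.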

Compound 4, inhibition constant: 150 nM
For compound 4 the middle estimate is 13-fold (1.10 log units) below the measured one; the whole stated range lies below it.
By their numbers in this assay, from the lowest: compound 2; then compound 3; then compound 4. At a limit, above all of these: compound 1.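

In this assay, among the compounds shown here, fluoro in place of cyano next to the ring nitrogen brings an 18-fold higher number from compound 3 to compound 4 (1.26 log units; beyond the scatter) and so shows that this position, which no earlier step touched, is sensitive to the group it carries. A single exchange on this ring can therefore move the number beyond the scatter, as the carbamoyl-to-cyano exchange did on the other ring. Nothing among the measurements shown accounts for the size of this step.

Going by these compounds, what a chloro group or an amine would give at this position stays open. Also open, on these data alone, is whether the same exchange would carry a similar step on the core of compound 2.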